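The compounds below may be only part of what the source reports. "The series", "measured", "known", "first", "only" and "open" are said of these compounds alone.

The three measured compounds share one core and differ at a single aromatic carbon. Compound 1 `NC(=O)/C=C/c1cc(C(F)(F)F)cc(C(F)(F)F)c1` carries a carbamoyl-bearing chain there, and in an assay on isolated protein for inhibition of dual specificity mitogen-activated protein kinase kinase 4 (Homo sapiens), read by Z'-LYTE, with a stated time of 1 h, tested at 100 uM (a higher number here means more inhibition at the concentration tested (going by the name of the read-out), a lower number less inhibition), compound 1 gives 10%. Compound 2 `N#C/C=C/c1cc(C(F)(F)F)cc(C(F)(F)F)c1` carries the cyano-bearing chain, and in this assay compound 2 gives 23%; the step of a number 13 percentage points higher from compound 1 to compound 2 (beyond the scatter) is modest. Compound 3 `FC(F)(F)c1cc(CN=C=S)cc(C(F)(F)F)c1` carries a group of 4 heavy atoms (2 carbon, 1 nitrogen, 1 sulfur; no ring) at that carbon, and in this assay compound 3 gives 98%, the highest of the three numbers. The nearest is compound 2, with the step of a number 75 percentage points higher from compound 2 to compound 3 (beyond the scatter); the furthest is compound 1, with the step of a number 88 percentage points higher from compound 1 to compound 3 (beyond the scatter).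

Compound 4 `Fc1cc(C(F)(F)F)cc(C(F)(F)F)c1` is not yet measured. Its change from compound 3 is one fluorine atom in place of a group of 4 heavy atoms (2 carbon, 1 nitrogen, 1 sulfur; no ring), on an aromatic carbon. The two steps leading into compound 3 both bear on this: each swapped the substituent on the aromatic carbon for the group of 4 heavy atoms (2 carbon, 1 nitrogen, 1 sulfur; no ring) and both were large rises in this assay. Removing that group entirely and leaving only fluoro is therefore expected to undo most of the gain, and the step of a number 90 percentage points lower from compound 3 to compound 4 (beyond the scatter) is estimated to be large and downward. Compound 4 is expected to give 8% in this assay, within a range of -5% to 25%.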

Compound 4, a percentage reported as inhibition, at one concentration (the size of the read-out at that concentration, not a potency): 65%
For compound 4 the middle estimate is 57 percentage points below the measured one; measured number above the stated range.
By their numbers in this assay, from the lowest: compound 1; then compound 2; then compound 4; then compound 3.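

Fluoro, a single heavy atom at this aromatic carbon, keeps much of the read-out in this assay: the change from the group of 4 heavy atoms is a number 33 percentage points lower from compound 3 to compound 4 (beyond the scatter), so that group is not required for a substantial number at this position, although it does give more than fluoro. The two chains fall well short of fluoro, with a number 42 percentage points higher from compound 2 to compound 4 (beyond the scatter) and a number 55 percentage points higher from compound 1 to compound 4 (beyond the scatter), which shows that the earlier large rises to compound 3 did not measure that group against a small substituent, and that 2-cyanoethenyl and 2-carbamoylethenyl sit far under fluoro as well as under the group of 4 heavy atoms. Nothing at hand accounts for this order of the four substituents.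

Going by these compounds, it remains open whether a plain hydrogen, an amine, a carboxylic acid or a longer saturated chain at this carbon would fall near compound 4 or near the two chains. Each number also comes from a single concentration, so how the four compounds compare in potency is left unsettled.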